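The compounds below may be only part of what the source reports. "The series", "measured", "known", "first", "only" and "open" are said of these compounds alone.

Measured compounds:
compound 1 `CCOC(=O)C1CN(C(C)=O)CCN1S(=O)(=O)c1ccc(F)cc1` — in a functional assay on the whole organism (strain CD-1) with Mus musculus as the target, with a stated time of 20 min (a higher number here means that more compound is needed for the effect, a lower number that less compound is needed), compound 1 gives 0.1 mg/kg
compound 2 `CC(=O)N1CCN(S(=O)(=O)c2ccc(F)cc2)C(CO)C1` — in this assay compound 2 gives 1 mg/kg

Going by the values given here, of the two numbers seen in this assay, compound 2 carries the highest; its nearest neighbour is compound 1, and the single measured step, a 10-fold higher number from compound 1 to compound 2 (1.00 log units; beyond the scatter), is beyond the scatter. Compound 3 `COCC1CN(C(C)=O)CCN1S(=O)(=O)c1ccc(F)cc1` is not yet measured. It differs from compound 2 in one place: methyl in place of hydrogen on an oxygen on a saturated carbon. Among the compounds with values here, no measured step shows this change; the only step known, a 10-fold higher number from compound 1 to compound 2 (1.00 log units; beyond the scatter), concerns a different group on a saturated ring carbon and bears on it only loosely, as a sign that this position can move the number. The account therefore expects for compound 3 a step of a 2.0-fold lower number from compound 2 to compound 3 (0.30 log units; within the scatter), toward a somewhat lower number but with wide uncertainty. In this assay compound 3 is estimated at 0.5 mg/kg, within a range from 0.1 mg/kg to 3 mg/kg.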

Compound 3, minimum effective dose in the Mus musculus assay: 1 mg/kg
For compound 3 the middle estimate is 2.0-fold (0.30 log units) below the measured one, and the stated range covers the measured number.
By their numbers in the Mus musculus assay, from the lowest: compound 1; then compounds 2 and 3 (each within the scatter of the next).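

In the Mus musculus assay, methyl in place of hydrogen on the oxygen of the hydroxymethyl group gives no change at the digits printed from compound 2 to compound 3 (within the scatter), so this change leaves the number where it was, and methoxymethyl in place of ethoxycarbonyl gives a 10-fold higher number from compound 1 to compound 3 (1.00 log units; beyond the scatter), the same size of step as the earlier one to hydroxymethyl. In a physicochemical assay for metabolic stability, read by LC-MS, in phosphate buffer, tested at 1 uM (a higher number here means that the compound lasts longer, a lower number that the compound disappears faster), compound 2 gives >= 4 h, which is a limit of the assay and not a number. In the physicochemical assay compound 3 gives >= 4 h, again a limit, so the step between these compounds cannot be read: the limit of >= 4 h in the physicochemical assay, at which 2 of the 2 values shown sit.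

The compounds shown leave open whether a longer chain on this oxygen would also leave the number in the Mus musculus assay unchanged. They also leave open where an amine or a carboxylic acid on the saturated ring carbon would fall.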